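Ester to amide on a biphenyl series

The compounds below may be only part of what the source reports. "The series", "measured", "known", "first", "only" and "open" are said of these compounds alone.

Compound 1 `CCCCOC(=O)c1cccc(-c2ccc(OCC)cc2)c1`: 61%
Compound 2 `CCOc1ccc(-c2cccc(C(=O)OCCOC)c2)cc1`: 89%

In an assay on COS-7 cells for inhibition of patatin-like phospholipase domain-containing protein 2 (Mus musculus), tested at 200 uM (on this read-out higher numbers stand for more inhibition at the one concentration tested (going by the name of the read-out) and lower numbers for less inhibition), compound 2 gives 89%, the higher of the two numbers recorded, while compound 1 gives 61%. For the measured compounds named here, the only step measured so far, a number 28 percentage points higher from compound 1 to compound 2 (beyond the scatter), changes the chain of the ester and leaves the carbonyl untouched. Compound 3 `CCOc1ccc(-c2cccc(C(=O)NC)c2)cc1` differs from compound 2 by methylamino in place of 2-methoxyethoxy on a carbonyl carbon, replacing the ester oxygen with an amide. Going by the values given here, no measured step bears on this change, so the expectation is loosely held: a drop beyond the scatter, a number 34 percentage points lower from compound 2 to compound 3 (beyond the scatter), is estimated for compound 3, giving 55% with a range from 20% to 90%.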

Compound 3, a percentage reported as inhibition, at one concentration (the size of the read-out at that concentration, not a potency): 40%
Beside the measured number, compound 3's estimate is 15 percentage points above it, within the range that was stated.
By their numbers in this assay, from the lowest: compound 3; then compound 1; then compound 2.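

In this assay, for the compounds shown here, methylamino in place of 2-methoxyethoxy on the carbonyl carbon gives a number 49 percentage points lower from compound 2 to compound 3 (beyond the scatter) and is the largest step so far, while methylamino in place of butoxy gives a number 21 percentage points lower from compound 1 to compound 3 (beyond the scatter) and points the same way. Both esters therefore stand above the amide compound 3, whichever chain they carry. No measurement here explains this drop.

Compound 3 changes both the atom on the carbonyl and the length of the group, so the effects of the two changes stay unseparated. From the compounds shown here alone, a 2-methoxyethylamino group on the same carbonyl carbon would pull them apart, and what a carboxylic acid would give there stays open.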